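This account rests on a few compounds, and the source may have more. Where it says the series, first, only, none or still open, it means among the compounds named here.

Measured in an ADME assay on S9 fraction from S9 cells (Zone of skin, Homo sapiens) for metabolic stability, read by HPLC, with a stated time of 180 min, tested at 0.5 uM; a lower number here means that the compound disappears faster, a higher number that the compound lasts longer:
compound 1, `CCC/N=C1\S/C(=C\c2ccc(OC(C)=O)c(C)c2)C(=O)N1c1ccccc1C`: 0.122 h
compound 2, `CCC/N=C1\S/C(=C\c2ccc(OC(=O)CCO)c(C)c2)C(=O)N1c1ccccc1C`: 0.137 h
compound 3, `CCC/N=C1\S/C(=C\c2ccc(OC(C)=O)c(C(F)(F)F)c2)C(=O)N1c1ccccc1C`: 0.138 h

Compound 1 has the lowest of the three half-lives, but both a 1.1-fold higher number from compound 1 to compound 2 (0.05 log units; within the scatter) and a 1.1-fold higher number from compound 1 to compound 3 (0.05 log units; within the scatter) fall within the scatter, so the three numbers cannot be told apart. Compound 4, `CCC/N=C1\S/C(=C\c2ccc(OC(=O)C(C)(C)C)c(C)c2)C(=O)N1c1ccccc1C`, is unmeasured; relative to compound 1 the change is tert-butyl in place of methyl on a carbonyl carbon. The step from compound 1 to compound 2 alters the same carbonyl-bearing group, with hydroxymethyl in place of hydrogen on a saturated chain carbon bound to a carbonyl carbon, and stayed flat; the step to compound 3, on an aromatic carbon, was equally flat. On that basis the expected step is a 1.1-fold higher number from compound 1 to compound 4 (0.03 log units; within the scatter), none beyond the scatter. Compound 4 is therefore estimated at 0.13 h, range 0.07 h to 0.25 h.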

Compound 4, half-life: > 3 h
Compound 4 gave a limit, no number; the forecaster's own chance of this, stated with the estimate: 5%; at least 23-fold (1.36 log units) between middle value and limit.
By their numbers in this assay, from the lowest: compounds 1, 2 and 3 (each within the scatter of the next). At a limit, above all of these: compound 4.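

Tert-butyl in place of methyl on this carbonyl carbon gives an at least 24-fold higher number from compound 1 to compound 4 (1.39 log units; beyond the scatter) and, set against 2-hydroxyethyl at the same place, an at least 21-fold higher number from compound 2 to compound 4 (1.34 log units; beyond the scatter) in this assay. The group on this carbonyl carbon can therefore move the half-life far beyond the scatter, which the flat change from methyl to 2-hydroxyethyl did not show. The full size of both steps cannot be read because compound 4 gave a limit, not a number: the limit of > 3 h in this assay, at which 1 of the 4 values shown sits.

Still open, going by these compounds, is whether isopropyl or cyclopropyl on the same carbonyl carbon reaches such a limit, or only tert-butyl does. Also open, on these data alone, is how tert-butyl behaves alongside trifluoromethyl on the aromatic carbon.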